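Thiophen-3-yl in Place of 4-(Trifluoromethyl)phenyl: Compound 4 Expected

A few compounds are considered here, and "the series" means these few. Any claim that something is new, unique, unknown or untested is made for them only; others in the source may bear on it.

Measured compounds in an assay on HL-60 cells for agonist activity at N-formyl peptide receptor 3 (Homo sapiens), read by calcium flux; a higher number here means that more compound is needed for the effect, a lower number that less compound is needed:
Compound 1, `Cc1cc(Cc2cccc(F)c2)c(=O)n(CC(=O)Nc2ccc(Br)cc2)n1`, gives a limit of > 50000 nM.
Compound 2, `Cc1cc(Cc2cccc(Cl)c2)c(=O)n(CC(=O)Nc2ccc(Br)cc2)n1`, gives a limit of > 50000 nM.
Compound 3, `Cc1cc(Cc2ccc(C(F)(F)F)cc2)c(=O)n(CC(=O)Nc2ccc(Br)cc2)n1`, gives a limit of > 50000 nM.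

All three values are limits of the assay, not numbers, as stated in the limit of > 50000 nM in this assay, at which 3 of the 3 values shown sit. Compound 3 therefore stands only at a limit, and the two other values shown are limits too. The step that the two limits leave unreadable from compound 1 to compound 2, the step that the two limits leave unreadable from compound 1 to compound 3 and the step that the two limits leave unreadable from compound 2 to compound 3 all remain unreadable in size, since both ends sit at the limit.

Compound 4, `Cc1cc(Cc2ccsc2)c(=O)n(CC(=O)Nc2ccc(Br)cc2)n1`, is not yet measured. The change is thiophen-3-yl in place of 4-(trifluoromethyl)phenyl on a saturated chain carbon bound to an aromatic carbon. Among the measured compounds shown here, none of the measured steps gives a readable size, so no direction can be drawn from them; all that the measured compounds show is that three different groups on the saturated chain carbon leave the value at the limit. Compound 4 is therefore expected to stay at the limit of this assay, with no step beyond the scatter that could be read. Compound 4 is estimated to give 50000 nM, with a range from 15000 nM to 200000 nM. This estimate means an expected step of a number no higher from compound 3 to compound 4 (the limit leaves the size open).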

Compound 4, half-maximal effective concentration: > 50000 nM
Compound 4: no number, only a limit; the forecaster's own chance of this, stated with the estimate: 85%; the middle value lies on the limit itself.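

In this assay compound 4 gives > 50000 nM, a limit and not a number. No step from compound 1, compound 2 or compound 3 to compound 4 can be read, since all four sit at the same limit: the limit of > 50000 nM in this assay, at which 4 of the 4 values shown sit.

The compounds shown leave open whether any group on the saturated chain carbon gives a readable value.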